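Swapping a dimethoxyphenyl for pyridin-4-yl: lipophilicity outlook

This account rests on a few compounds, and the source may have more. Where it says the series, first, only, none or still open, it means among the compounds named here.

Three compounds share one core and differ only in the aryl group attached to the carbon double-bonded to nitrogen. Compound 1 `O=C(NNc1ccnc2cc(Cl)ccc12)c1ccccc1/N=C/c1cccc(Cl)c1Cl` gives 6.1 in a physicochemical assay for lipophilicity, measured as octanol-water partition (on this read-out higher numbers stand for higher lipophilicity and lower numbers for lower lipophilicity), and compound 2 `O=C(NNc1ccnc2cc(Cl)ccc12)c1ccccc1/N=C/c1ccc(Cl)c(Cl)c1` gives 6.22, with the step of a number 0.12 log units higher from compound 1 to compound 2 (within the scatter). Compound 3 `COc1ccc(/C=N/c2ccccc2C(=O)NNc2ccnc3cc(Cl)ccc23)cc1OC` gives 4.97, the lowest of the three numbers: the steps of a number 1.13 log units lower from compound 1 to compound 3 (beyond the scatter) and a number 1.25 log units lower from compound 2 to compound 3 (beyond the scatter) are both large.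

Compound 4 `O=C(NNc1ccnc2cc(Cl)ccc12)c1ccccc1/N=C/c1ccncc1` has not yet been measured in this assay. Its change from compound 3 is pyridin-4-yl in place of 3,4-dimethoxyphenyl on a carbon with a double bond to nitrogen. For the measured compounds named here, no measured step covers a pyridin-4-yl group, so the only guidance is that the one change of aryl group seen so far, from dichlorophenyl to dimethoxyphenyl, moved the number down by more than one unit, while the two dichlorophenyl isomers sat within the scatter of each other. Compound 4 is therefore expected to fall further, by about a number 1.37 log units lower from compound 3 to compound 4 (beyond the scatter), giving an estimated 3.6 with a range from 3 to 4.2.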

Compound 4, partition coefficient: 3.86
Compound 4: the middle estimate sits 0.26 log units below what was measured; the range from low to high includes it.
By their numbers in this assay, from the lowest: compound 4; then compound 3; then compounds 1 and 2 (each within the scatter of the next).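

In this assay, this position keeps responding when the entering ring holds a hetero atom: pyridin-4-yl brings a further large step down from the dimethoxy compound (a number 1.11 log units lower from compound 3 to compound 4 (beyond the scatter)). Set against the two dichlorophenyl compounds, the steps (a number 2.36 log units lower from compound 2 to compound 4 (beyond the scatter); a number 2.24 log units lower from compound 1 to compound 4 (beyond the scatter)) are larger than any seen before, so the aryl group on this carbon can shift the number by much more than the earlier compounds showed. Nothing measured here bears on why the number fell.

This change swaps the ring carbon for a ring nitrogen and also removes both methoxy groups, so the compounds shown cannot separate these two parts of it. Plain phenyl would help to do so, while pyridin-3-yl or a phenyl ring carrying an amine would show how far the trend extends.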